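A few compounds are considered here, and "the series" means these few. Any claim that something is new, unique, unknown or untested is made for them only; others in the source may bear on it.

Three measured compounds share one core and are compared in a single cell-based test. Compound 1 `COc1cc2c(Oc3ccc(NC(=O)N/N=C/c4ccc(O)cc4)cc3F)ccnc2cc1OCCCN1CCCCC1` gives 850 nM in a functional assay on MKN-45 cells (Homo sapiens) for cytotoxicity, read by MTT assay, with a stated time of 72 h; a lower number here means a stronger inhibitor, a higher number a weaker inhibitor. Compound 2 `COc1cc2c(Oc3ccc(NC(=O)N/N=C/c4cccs4)cc3F)ccnc2cc1OCCCN1CCCCC1` gives 740 nM in this assay, and the step of a 1.1-fold lower number from compound 1 to compound 2 (0.06 log units; within the scatter) exchanges one group for another on the carbon with a double bond to nitrogen. Compound 3 `COc1cc2c(Oc3ccc(NC(=S)N/N=C/c4ccc(F)c(F)c4)cc3F)ccnc2cc1OCCCN1CCCCC1` gives 740 nM in this assay, level with compound 2 and within the scatter of compound 1. Compound 4 `COc1cc2c(Oc3ccc(NC(=S)N/N=C/c4ccc(Cl)cc4)cc3F)ccnc2cc1OCCCN1CCCCC1` differs from compound 3 by 4-chlorophenyl in place of 3,4-difluorophenyl on a carbon with a double bond to nitrogen. Going by the values given here, no measured pair shows this exact exchange; the only step at this place, a 1.1-fold lower number from compound 1 to compound 2 (0.06 log units; within the scatter), stayed within the scatter, so for compound 4 the expected step is no change at the digits printed from compound 3 to compound 4 (within the scatter) in this assay. Compound 4 is therefore estimated at 740 nM, between 370 nM and 1500 nM.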

Compound 4, half-maximal inhibitory concentration: 500 nM
For compound 4 the middle estimate is 1.5-fold (0.17 log units) above the measured one; the measured number falls inside the stated range.
By their numbers in this assay, from the lowest: compounds 4, 2, 3 and 1 (each within the scatter of the next).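

In this assay, 4-chlorophenyl in place of 3,4-difluorophenyl on this carbon gives a 1.5-fold lower number from compound 3 to compound 4 (0.17 log units; within the scatter) and so shows that this exchange of ring substituents leaves the number within the scatter. The wider exchanges on the nitrogen on an aromatic ring give a 1.5-fold lower number from compound 2 to compound 4 (0.17 log units; within the scatter) and a 1.7-fold lower number from compound 1 to compound 4 (0.23 log units; within the scatter) and also stay within the scatter. Nothing measured here offers an explanation for these results.

Every group shown on this carbon is an aromatic ring, so the effect of an amine, a carboxylic acid or a butyl chain there remains open. Also open, going by these compounds, is what exchanging carbonyl for thiocarbonyl does when the ring stays the same.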